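Methyl on the anilide ring of a furan-carboxamide series

The compounds below may be only part of what the source reports. "The series", "measured", "known", "first", "only" and "open" are said of these compounds alone.

Among the compounds with values here, the two measured members are compound 1, `Cc1ccoc1C(=O)Nc1cccc(-c2nc3ncccc3o2)c1`, and compound 2, `O=C(Nc1ccc(F)c(-c2nc3ncccc3o2)c1)c1ccoc1`. Both were run in an ADME assay on microsomes from liver (Homo sapiens) for metabolic stability, read by LC-MS, with a stated time of 60 min, tested at 1 uM; a lower number here means slower removal, a higher number faster removal of the compound. In this assay compound 1 gives 181 mL.min-1.g-1, and compound 2 gives 154 mL.min-1.g-1. Within the data shown here, compound 1 has the higher of the two numbers, but compound 2 sits within the scatter of it, so the two are not told apart by this assay; no step between measured compounds that differ in one place has been computed.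

The next member is compound 3, `Cc1ccc(NC(=O)c2occc2C)cc1-c1nc2ncccc2o1`. Relative to compound 1 it differs by methyl in place of hydrogen on an aromatic carbon. Among the measured compounds shown here, the data hold no measured step for this kind of change, so there is nothing to anchor its size on; the expectation is that the change from compound 1 to compound 3 stays within the scatter, with no clear direction. Compound 3 is therefore expected to give about 200 mL.min-1.g-1 in this assay, within a range of 110 mL.min-1.g-1 to 380 mL.min-1.g-1. Against compound 1 this estimate means a step of a 1.1-fold higher number from compound 1 to compound 3 (0.04 log units; within the scatter).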

Compound 3, intrinsic clearance in microsomes in the Homo sapiens assay: 228 mL.min-1.g-1
The estimate for compound 3 lay 1.1-fold (0.06 log units) below the measured number; measured number inside the range.
By their numbers in the Homo sapiens assay, from the lowest: compounds 2, 1 and 3 (each within the scatter of the next).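

Methyl in place of hydrogen on an aromatic carbon, ortho to a group of 9 heavy atoms and para to a group of 9 heavy atoms, now has its first measured step: in the Homo sapiens assay the change is a 1.3-fold higher number from compound 1 to compound 3 (0.10 log units; within the scatter), so this position, with this group, does not separate the two compounds on removal. In a physicochemical assay for solubility, read by nephelometry, in phosphate buffer, measured as kinetic solubility, at pH 2 (a lower number here means a less soluble compound, a higher number a more soluble compound), compound 1 gives 6.3 ug/mL and compound 3 gives 1.6 ug/mL. The same single change that cannot be read in removal can therefore be read in solubility, where the methyl carries a cost beyond the scatter: the measured solubility of compound 1, 6.3 ug/mL, and of compound 3, 1.6 ug/mL, a 3.9-fold lower number (0.60 log units; beyond the scatter)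

All of this rests on one pair of compounds, so it holds for methyl at this one place and sets no pattern for the series. Going by these compounds, whether an amine or a carboxylic acid on this aromatic carbon would give a different number in the Homo sapiens assay or in the physicochemical assay remains open, as does the effect of a longer chain there.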